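Butyl in Place of Hydrogen on Compound 2

The source may report more compounds than this note shows. Statements on the series, on what has been measured and on what is new or still open speak of the compounds shown alone.

The series is read in a functional assay on cells (Splenocyte, Mus musculus, strain BALB/c) for inhibition, read by scintillation counting and thymidine incorporation, with stated times of 48 h and 8 h; on this read-out higher numbers stand for weaker inhibition and lower numbers for stronger inhibition. Compound 1 `COc1cc(OC)cc(-c2nc(Cc3c[nH]c4ccccc34)no2)c1` gives > 50000 nM in this assay, a limit of the assay rather than a number. Compound 2 `COc1cc(-c2noc(-c3ccccc3)n2)cc(OC)c1OC` likewise stands at > 50000 nM in this assay, again a limit and not a number, so its position is only bounded from one side; (the limit of > 50000 nM in this assay, at which 2 of the 3 values shown sit). Going by the values given here, compound 3 `COc1cc(-c2noc(-c3cccc(N)c3)n2)cc(OC)c1OC` gives 7000 nM in this assay, and the step of an at least 7.1-fold lower number from compound 2 to compound 3 (0.85 log units; beyond the scatter) is the only measured change of one place. Compound 4 `CCCCc1ccc(-c2nc(-c3cc(OC)c(OC)c(OC)c3)no2)cc1` differs from compound 2 by butyl in place of hydrogen on an aromatic carbon. Among the compounds with values here, the amino step concerns a different group and bears only loosely on the butyl change, so no measured step tells what butyl does here. Compound 4 is therefore expected to remain near the limit, with a number no higher from compound 2 to compound 4 (the limit leaves the size open) as the expected step. The estimate for compound 4 in this assay is 50000 nM, expected between 10000 nM and 100000 nM.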

Compound 4, half-maximal inhibitory concentration: > 50000 nM
Compound 4: only a limit was reported; the forecaster's own chance of this, stated with the estimate: 60%; the middle value lies on the limit itself.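

Compound 4 gives > 50000 nM, a limit and not a number. Compound 2 also stands at a limit, so no step can be read between compound 2 and compound 4. The compounds shown leave open what butyl in place of hydrogen does to inhibition.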